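The source may hold more compounds than are shown below. What is called first, only, known or untested is meant among the compounds shown, and "the series" means these compounds.

Compound 1 `COc1ccc(C(C)C)c2c1C(=O)C(O)(O)C2=O` in an assay on isolated protein for inhibition of carbonic anhydrase 4 (Homo sapiens), read by stopped-flow, with a stated time of 15 min (on this read-out higher numbers stand for weaker inhibition and lower numbers for stronger inhibition), gives only the assay's limit, > 100000 nM.
Compound 2 `COc1ccc(CNC(=O)CCl)c2c1C(=O)C(O)(O)C2=O` in this assay gives only the assay's limit, > 100000 nM.

Compound 2 therefore stands at a limit rather than at a number, and every value shown sits at the same place (the limit of > 100000 nM in this assay, at which 2 of the 2 values shown sit). Within the data shown here, the single measured step, a step that the two limits leave unreadable from compound 1 to compound 2, runs between two limits, so its size cannot be read. Compound 3 `COc1ccc(OC)c2c1C(=O)C(O)(O)C2=O` differs from compound 2 by methoxy in place of (((chloromethyl)carbonyl)amino)methyl on an aromatic carbon. Among the measured compounds shown here, no measured step informs this change, so no shift in this assay beyond the scatter can be claimed. Compound 3 is expected to give 200000 nM, within 50000 nM to 1000000 nM, most probably again as a limit. The expected step is a step that the limit leaves unreadable from compound 2 to compound 3.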

Compound 3, inhibition constant: > 100000 nM
Compound 3 ended at the assay's limit (the forecaster's own chance of this, stated with the estimate: 85%); the middle value lies beyond the limit too.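

Compound 1, compound 2 and compound 3 all end at a limit rather than at a number, so no step among them can be read: the limit of > 100000 nM in this assay, at which 3 of the 3 values shown sit.

The compounds shown leave open which change to the shared core, if any, would give a measurable value in this assay.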